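A few compounds are considered here, and "the series" means these few. Any claim that something is new, unique, unknown or untested is made for them only; others in the source may bear on it.

For the measured compounds named here, in a physicochemical assay for solubility (on this read-out higher numbers stand for higher solubility and lower numbers for lower solubility), compound 2 `O=C(Nc1ccc(F)cc1Cl)c1cc(Cl)ccc1O` gives 1.2 ug/mL, the only actual number so far. Compound 1 `N#Cc1ccc(NC(=O)c2cc(Cl)ccc2O)c(Cl)c1` reads < 1 ug/mL, which is a limit of the assay and not a number. Compound 3 `O=C(Nc1ccc(F)cc1F)c1cc(Cl)ccc1O` differs from compound 2 through fluoro in place of chloro on an aromatic carbon, ortho to a large group and meta to a fluoro group. Going by the values given here, only one measured step offers any guide, and it is a different exchange, fluoro in place of cyano on an aromatic carbon: an at least 1.2-fold higher number from compound 1 to compound 2 (0.07 log units; that floor lies within the scatter). That step shows no size beyond the scatter, so no step beyond the scatter is expected in this assay, in either direction. The expected change is a 1.5-fold higher number from compound 2 to compound 3 (0.18 log units; within the scatter). For compound 3 the estimated value is 1.8 ug/mL, with an expected range from 0.8 ug/mL to 5 ug/mL.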

Compound 3, solubility: 1 ug/mL
Compound 3: the middle estimate sits 1.8-fold (0.26 log units) above what was measured; low and high end bracket the measured number.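

In this assay, fluoro in place of chloro on an aromatic carbon, ortho to a large group and meta to a fluoro group, gives a 1.2-fold lower number from compound 2 to compound 3 (0.08 log units; within the scatter). This is the first step shown with an actual number at both ends, and it shows that this exchange leaves the reading within the scatter at this position. That reading has little room left beneath it, because the value of compound 3 stands at the same number as the limit of the assay: the limit of < 1 ug/mL in this assay, at which 1 of the 3 values shown sits.

From the compounds shown here alone, it remains open whether an amine, a carboxylic acid or a methoxy group at this position would move the reading in this assay beyond the scatter. Going by these compounds, the value of compound 1, < 1 ug/mL, is a limit and not a number, so its actual size also stays open.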